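Three Benzoxazole Sulfonamides and an Unmeasured Fourth

This account rests on a few compounds, and the source may have more. Where it says the series, first, only, none or still open, it means among the compounds named here.

Compound 1 `O=S(=O)(Nc1ccc(-c2nc3ccccc3o2)cc1)c1ccccc1Cl` in an assay on isolated protein for inhibition of malate dehydrogenase, mitochondrial (Sus scrofa), with stated times of 45 min and 30 min (a higher number here means a weaker inhibitor, a lower number a stronger inhibitor), gives > 63000 nM, which is a limit of the assay rather than a number.
Compound 2 `O=S(=O)(Nc1ccc(-c2nc3ccccc3o2)cc1)c1cccc(Cl)c1` in this assay gives > 63000 nM, again a limit of the assay.
Compound 3 `O=S(=O)(Nc1ccc2oc(-c3ccccc3)nc2c1)c1cccc(Cl)c1` in this assay gives > 63000 nM, also a limit of the assay.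

All three measured compounds sit at the same limit, which is the state of things described by the limit of > 63000 nM in this assay, at which 3 of the 3 values shown sit. Compound 1 and compound 2 share a core and differ only in the ring on the sulfonyl sulfur: 2-chlorophenyl in place of 3-chlorophenyl on a sulfonyl sulfur. Because both values are limits, the step that the two limits leave unreadable from compound 2 to compound 1 cannot be read in size; all that can be said is that neither compound reached a measurable inhibition. Compound 3 carries a different core from compound 2, and the difference between the two cores is not broken down here.

Compound 4 `O=S(=O)(Nc1ccc2oc(-c3ccccc3)nc2c1)c1ccccc1Cl` has not yet been measured. It stands to compound 3 as compound 1 stands to compound 2: 2-chlorophenyl in place of 3-chlorophenyl on a sulfonyl sulfur. The place of the change is the same in both pairs, a sulfonyl sulfur whose other neighbour is the sulfonamide nitrogen, so this is the same change made on a second core.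

The expectation rests on compound 3, whose value of > 63000 nM is a limit, and on the fact that the same change from compound 2 to compound 1 gave two limits, so the step from compound 3 to compound 4 is expected to be about a step that the limit leaves unreadable from compound 3 to compound 4. For compound 4 in this assay the estimated value is 100000 nM, with a range from 40000 nM to 400000 nM, and most likely the assay will again report only a limit.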

Compound 4, half-maximal inhibitory concentration: > 63000 nM
Compound 4 gave a limit, no number; the forecaster's own chance of this, stated with the estimate: 85%; the middle value does not contradict the limit.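

Compound 3 and compound 4 each give only a limit of the assay in this assay, not a number, so the size of the step between them cannot be read. All four compounds now stand at the same point: the limit of > 63000 nM in this assay, at which 4 of the 4 values shown sit. The compounds shown leave open whether any structure in this series gives a measurable inhibition, and how 2-chlorophenyl and 3-chlorophenyl would then compare.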